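A few compounds are considered here, and "the series" means these few. Any claim that something is new, unique, unknown or untested is made for them only; others in the source may bear on it.

Compound 1 `COc1cc(-c2nnc3n2NC(c2ccco2)C(C(=O)c2ccccc2C)S3)cc(OC)c1OC` gives 63000 nM in a functional assay on HepG2 cells (Homo sapiens) for cytotoxicity, read by MTT assay, with a stated time of 48 h; a lower number here means a stronger inhibitor, a higher number a weaker inhibitor. For compound 2 `COc1cc(-c2nnc3n2NC(c2ccco2)C(C(=O)C2CC2)S3)cc(OC)c1OC` this assay reports only a limit, > 100000 nM, namely (the limit of > 100000 nM in this assay, at which 1 of the 2 values shown sits). The measured step of an at least 1.5-fold higher number from compound 1 to compound 2 (0.20 log units; that floor lies within the scatter) is therefore itself only a floor. Compound 3 `COc1cc(-c2nnc3n2NC(c2ccco2)C(C(=O)c2ccccc2)S3)cc(OC)c1OC` carries phenyl in place of cyclopropyl on a carbonyl carbon. Within the data shown here, only that one step bears on this change, and it points back toward the aromatic ketone of compound 1, whose number is 63000 nM. Compound 3 is expected to give roughly 70000 nM, within 30000 nM to 150000 nM. The expected step of an at least 1.4-fold lower number from compound 2 to compound 3 (0.15 log units; that floor lies within the scatter) is thus a lower number, though a limit remains possible.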

Compound 3, half-maximal inhibitory concentration: 90900 nM
For compound 3 the middle estimate is 1.3-fold (0.11 log units) below the measured one; measured number inside the range.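

Phenyl in place of cyclopropyl on a carbonyl carbon gives an at least 1.1-fold lower number from compound 2 to compound 3 (0.04 log units; that floor lies within the scatter) and so adds no readable separation between these two ketones. That step is only a floor, and the limit belongs to compound 2: the limit of > 100000 nM in this assay, at which 1 of the 3 values shown sits. Hydrogen in place of methyl on an aromatic carbon gives a 1.4-fold higher number from compound 1 to compound 3 (0.16 log units; within the scatter) in this assay and so does not separate the two aromatic ketones.

Going by these compounds, the true size of the cyclopropyl to phenyl step stays open. Also open, on these data alone, is whether an amine or a carboxylic acid on the phenyl ring would give a step beyond the scatter.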